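A few compounds are considered here, and "the series" means these few. Any claim that something is new, unique, unknown or untested is made for them only; others in the source may bear on it.

Working notes on the series. Compound 1 `O=C(Nc1cccc(-n2cc(-c3ccncc3)c(-c3ccc(Cl)c(O)c3)n2)c1)Nc1cccc(C(F)(F)F)c1` in a functional assay on RPMI-8226 cells (Homo sapiens) for inhibition, read by sulforhodamine B assay, with a stated time of 48 h (on this read-out lower numbers stand for higher toxicity in this test and higher numbers for lower toxicity in this test), gives > 32500 nM, which is a limit of the assay rather than a number. Compound 2 `COc1cc(-c2nn(-c3cccc(NC(=O)Nc4cc(C(F)(F)F)cc(C(F)(F)F)c4)c3)cc2-c2ccncc2)ccc1Cl` gives > 50000 nM, likewise a limit. Compound 3 `COc1cc(-c2nn(-c3cccc(NC(=O)Nc4cccc(C(F)(F)F)c4)c3)cc2-c2ccncc2)ccc1Cl` gives > 50000 nM, also a limit. Compound 2 therefore stands at a limit, as do the two other values shown. The step that the two limits leave unreadable from compound 1 to compound 3 and the step that the two limits leave unreadable from compound 2 to compound 3 are both unreadable because the limit of > 32500 nM in this assay, at which 1 of the 3 values shown sits, and the limit of > 50000 nM in this assay, at which 2 of the 3 values shown sit, bound them on either side. Compound 4 `O=C(Nc1cccc(-n2cc(-c3ccncc3)c(-c3ccc(Cl)c(O)c3)n2)c1)Nc1cc(C(F)(F)F)cc(C(F)(F)F)c1` differs from compound 2 by hydrogen in place of methyl on an oxygen on an aromatic ring. No readable step bears on this change, so nothing beyond the scatter is expected in this assay, with a further limit the most likely outcome. Compound 4 is expected near 50000 nM, between 20000 nM and 120000 nM. The expected step is a number no higher from compound 2 to compound 4 (the limit leaves the size open).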

Compound 4, concentration lethal to 50% of the cells: > 50000 nM
Compound 4: a limit, no number; the forecaster's own chance of this, stated with the estimate: 85%; the middle value sits exactly at the limit.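

Neither the step between compound 2 and compound 4 nor that between compound 1 and compound 4 can be read, as all these values are limits. The compounds shown leave open whether methoxy to hydroxy or the added trifluoromethyl changes anything in this assay.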